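Swapping bromo for methyl on a fused-ring diketone core

The source may hold more compounds than are shown below. What is called first, only, known or untested is meant among the compounds shown, and "the series" means these compounds.

Compound 3 `O=C(CC(=O)c1cc(Br)ccc1O)c1cc2ccccc2s1` belongs to a small set sharing one core, and in an ADME assay on THP-1 cells (Homo sapiens) for inhibition, read by MTT assay, with a stated time of 72 h (a higher number here means a weaker inhibitor of growth, a lower number a stronger inhibitor of growth), compound 3 gives only a limit of the assay, > 100 ug/mL. Its neighbours set the frame: compound 1 `O=C(CC(=O)c1ccccc1O)c1cc2ccccc2s1` carries hydrogen at the same position. In this assay compound 1 also gives a limit, > 100 ug/mL. Compound 2 `O=C(CC(=O)c1cc(Cl)ccc1O)c1cc2ccccc2s1` carries chloro there, and in this assay compound 2 gives a number, 7.48 ug/mL. The measured steps are therefore a drop of an at least 13-fold lower number from compound 1 to compound 2 (1.12 log units; beyond the scatter) and a rise of an at least 13-fold higher number from compound 2 to compound 3 (1.12 log units; beyond the scatter), both beyond the scatter, while a step that the two limits leave unreadable from compound 1 to compound 3. Two of the three values sit at the same boundary, namely (the limit of > 100 ug/mL in this assay, at which 2 of the 3 values shown sit).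

Compound 4 `Cc1ccc(O)c(C(=O)CC(=O)c2cc3ccccc3s2)c1` differs from compound 3 by methyl in place of bromo on an aromatic carbon. Only chloro has so far produced a readable number, and both hydrogen and bromo left the assay at its limit. The step from bromo to methyl is expected to give an at least 2.0-fold lower number from compound 3 to compound 4 (0.30 log units; that floor lies within the scatter), with a real chance of another limit. Compound 4 is estimated at 50 ug/mL, between 8 ug/mL and 150 ug/mL.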

Compound 4, concentration for 50% growth inhibition: > 100 ug/mL
Compound 4: no number, only a limit; the forecaster's own chance of this, stated with the estimate: 55%; at least 2.0-fold (0.30 log units) between middle value and limit.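

Methyl at this position, para to a hydroxy group, now joins hydrogen and bromo at the limit, so chloro in compound 2 is the only one of the four groups that gives a number in this assay. Exchanging that chloro for methyl gives an at least 13-fold higher number from compound 2 to compound 4 (1.12 log units; beyond the scatter), so the readable result at this position belongs to chloro alone among the groups shown. The steps from compound 1 and from compound 3 to compound 4 cannot be read, because both ends of each step are limits rather than numbers, and hydrogen, bromo and methyl therefore cannot be ranked: the limit of > 100 ug/mL in this assay, at which 3 of the 4 values shown sit.

From the compounds shown here alone, whether any other group at this position gives a number remains open, for example fluoro, methoxy or an amine. Going by these compounds, it is also open whether chloro would give a similar number at another place on the same ring.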